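Isopropyl for hydroxycyclohexyl on the shared core

The source may hold more compounds than are shown below. What is called first, only, known or untested is meant among the compounds shown, and "the series" means these compounds.

Compound 1 `CN1CCN(c2ccc(Nc3ncc4nc([S+]([O-])c5ccccc5)n([C@H]5CC[C@H](O)CC5)c4n3)cc2)CC1` gives 268 nM in a functional assay on HCC827 cells (Homo sapiens) for antiproliferative activity, read by MTT assay, with a stated time of 72 h (a higher number here means a weaker inhibitor, a lower number a stronger inhibitor), the smaller of the two numbers in hand; compound 2 `CN1CCN(c2ccc(Nc3ncc4nc([S+]([O-])Cc5ccccc5)n(C5CCOCC5)c4n3)cc2)CC1` gives 433 nM in this assay, a gap that sits within the scatter, so the two cannot be ranked. Compound 3 `CC(C)n1c([S+]([O-])c2ccccc2)nc2cnc(Nc3ccc(N4CCN(C)CC4)cc3)nc21` differs from compound 1 by isopropyl in place of 4-hydroxycyclohexyl on an aromatic nitrogen. For the measured compounds named here, no step between measured compounds shows what this change does on the shared core. A shift toward a higher number at most modest in size is expected, giving a step of a 1.4-fold higher number from compound 1 to compound 3 (0.15 log units; within the scatter) in this assay. Compound 3 is estimated at 380 nM, within a range from 130 nM to 1100 nM.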

Compound 3, half-maximal inhibitory concentration: 215 nM
Compound 3: middle estimate off by 1.8-fold (0.25 log units), on the high side; the range from low to high includes it.
By their numbers in this assay, from the lowest: compounds 3, 1 and 2 (each within the scatter of the next).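

Putting isopropyl in place of 4-hydroxycyclohexyl on the aromatic nitrogen gives a 1.2-fold lower number from compound 1 to compound 3 (0.10 log units; within the scatter) in this assay. On the shared core, this position therefore accepts the loss of the six-membered non-aromatic ring, its hydrogen-bond donor and acceptor, and both defined stereocentres, with no shift beyond the scatter. Nothing on hand accounts for this result. Still open, on these data alone, is whether a group such as methyl, or a longer chain ending in an amine or a carboxylic acid, would stay within the scatter at this nitrogen.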